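Returning an Oxygen-Linked Chain at a Shorter Length

The compounds below may be only part of what the source reports. "The series", "measured", "known", "first", "only" and "open" are said of these compounds alone.

Of the compounds shown here, three sharing one core have been measured in a functional assay (spleen, spleen) for activation, with Mus musculus as the target; a higher number here means that more compound is needed for the effect, a lower number that less compound is needed. Compound 1 `CCCCCOc1nc(N)c2nc(O)n(Cc3ccccc3)c2n1` gives 0.01 uM in this assay. Compound 2 `CCCCCSc1nc(N)c2nc(O)n(Cc3ccccc3)c2n1` gives 10 uM. Compound 3 `CCCCc1nc(N)c2nc(O)n(Cc3ccccc3)c2n1` gives 0.03 uM, which places it second highest of the three numbers: a 3.0-fold higher number from compound 1 to compound 3 (0.48 log units; beyond the scatter) separates it from compound 1, and a 330-fold lower number from compound 2 to compound 3 (2.52 log units; beyond the scatter) separates it from compound 2.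

Compound 4 `CCCOc1nc(N)c2nc(O)n(Cc3ccccc3)c2n1` has not been measured. It differs from compound 3 in one place: propoxy in place of butyl on an aromatic carbon. Among the measured compounds shown here, two measured steps bear on this. Replacing pentyloxy by butyl gave a 3.0-fold higher number from compound 1 to compound 3 (0.48 log units; beyond the scatter), a modest rise. Replacing pentyloxy by pentylsulfanyl gave a 1000-fold higher number from compound 1 to compound 2 (3.00 log units; beyond the scatter), a large rise, showing that the atom joining the chain to the ring matters greatly. For the measured compounds named here, compound 4 brings back an oxygen-joined chain, as in compound 1, but the chain is shorter than in compound 1, and no measured pair shows what shortening the chain does. The oxygen for carbon part of the change alone would suggest a number somewhat below that of compound 3, while the unknown effect of the shorter chain widens the uncertainty. Compound 4 is therefore expected to give about 0.02 uM, within 0.004 uM to 0.15 uM, an expected step of a 1.5-fold lower number from compound 3 to compound 4 (0.18 log units; within the scatter).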

Compound 4, minimum effective concentration: 0.01 uM
Compound 4: the middle estimate sits 2.0-fold (0.30 log units) above what was measured, and the stated range covers the measured number.
By their numbers in this assay, from the lowest: compounds 1 and 4 (each within the scatter of the next); then compound 3; then compound 2.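

Going from pentyloxy to the shorter propoxy chain leaves the number in this assay unchanged within the scatter (no change at the digits printed from compound 1 to compound 4 (within the scatter)), so these two oxygen-joined chains cannot be told apart at this position, on a carbon between two ring nitrogen atoms. Butyl and propoxy have the same heavy-atom count, and propoxy carries one hydrogen-bond acceptor that butyl lacks, yet this exchange, which in effect puts an oxygen at the joining point, still moves the number (a 3.0-fold lower number from compound 3 to compound 4 (0.48 log units; beyond the scatter)), showing that the joining atom matters here even when the heavy-atom count stays the same. The sulfur-joined chain of compound 2 stays far from this short oxygen-joined chain (a 1000-fold lower number from compound 2 to compound 4 (3.00 log units; beyond the scatter)), although that comparison changes chain length as well as the joining atom.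

Nothing in the data explains why the joining atom has such an effect. On these data alone, it remains open whether an ethoxy or methoxy chain would hold the number as propoxy does, whether a longer hexyloxy chain would do the same, and how a chain joined through an amine nitrogen would compare with the oxygen-joined ones.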